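The source may report more compounds than this note shows. Statements on the series, on what has been measured and on what is new or still open speak of the compounds shown alone.

Of the compounds shown here, three sharing one core have been measured in a functional assay on HL-60 cells (Homo sapiens) for cytotoxicity, read by WST assay, with a stated time of 48 h; a higher number here means that more compound is needed for the effect, a lower number that less compound is needed. Compound 3 `O=C1OC[C@H](Cc2ccccc2O)[C@H]1Cc1ccc(Cl)c(Cl)c1` gives 33000 nM in this assay. Among the two values that are numbers, that of compound 3 is the lowest, but its nearest neighbour, compound 1 `O=C1OC[C@H](Cc2ccccc2)[C@H]1Cc1cccc(C(F)(F)F)c1` with 34000 nM in this assay, sits within the usual scatter, so the two cannot be told apart. Compound 2 `CCCCCCCOc1ccc(C[C@H]2C(=O)OC[C@@H]2Cc2ccccc2)cc1` reaches only a limit of the assay, > 100000 nM in this assay, and no number is known for it. That one of the three values is such a limit is noted as the limit of > 100000 nM in this assay, at which 1 of the 3 values shown sits.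

Compound 4 `O=C1OC[C@H](Cc2ccc(F)c(F)c2)[C@H]1Cc1ccc(Cl)c(Cl)c1` has not yet been measured in this assay. It differs from compound 3 in one place: 3,4-difluorophenyl in place of 2-hydroxyphenyl on a saturated chain carbon bound to a saturated ring carbon. Within the data shown here, no step between two measured compounds of this kind is available, so there is no measured guide for the size or direction of the change. Given that the two numbers known so far lie within the scatter of each other, the expected step in this assay from compound 3 to compound 4 is estimated as a 1.1-fold higher number from compound 3 to compound 4 (0.03 log units; within the scatter), that is none beyond the scatter. Compound 4 is therefore expected to give about 35000 nM in this assay, in a range from 12000 nM to 100000 nM.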

Compound 4, half-maximal effective concentration: 25000 nM
The estimate for compound 4 lay 1.4-fold (0.15 log units) above the measured number; the measured number falls inside the stated range.
By their numbers in this assay, from the lowest: compounds 4, 3 and 1 (each within the scatter of the next). At a limit, above all of these: compound 2.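

Among these compounds, compound 3 and compound 4 give the first measured step at this place, on a saturated chain carbon bound to a saturated ring carbon: with 3,4-difluorophenyl in place of 2-hydroxyphenyl, this assay shows a 1.3-fold lower number from compound 3 to compound 4 (0.12 log units; within the scatter). The swap removes the only hydrogen-bond donor and acceptor counted for the leaving group, since 2-hydroxyphenyl has one of each and 3,4-difluorophenyl has neither, yet the number does not move beyond the scatter, so this one pair gives no sign that the hydroxyl matters for the read-out. Nothing measured for these compounds accounts for how small the step is.

From the compounds shown here alone, whether a quite different group at this place, such as an amine, a carboxylic acid or a longer chain, would move the number beyond the scatter stays open, as does whether this single step would hold with other groups elsewhere on the shared core. Compound 2 stays at a limit of the assay, > 100000 nM, which is not a number, and it differs from the others in more than one place, so it offers no comparison for this position.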